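Swapping Chlorine for Methyl on a Benzylamine

The source may hold more compounds than are shown below. What is called first, only, known or untested is meant among the compounds shown, and "the series" means these compounds.

Measured compounds:
compound 1, `Cc1cc(CNCc2ccc(Cl)cc2)c(C)n1-c1ccc(Cl)cc1`, gives 0.1 ug/mL in an ADME assay on RAW264.7 cells (Mus musculus) for cytotoxicity, read by trypan blue exclusion, with a stated time of 48 h; on this read-out higher numbers stand for weaker inhibition of growth and lower numbers for stronger inhibition of growth
compound 2, `Cc1cc(CN2CCN(c3ccccc3)CC2)c(C)n1-c1ccc(Cl)cc1`, gives 33 ug/mL in this assay
compound 3, `Cc1c(CN2CCN(c3ccccc3)CC2)c(CN2CCN(c3ccccc3)CC2)c(C)n1-c1ccc(Cl)cc1`, gives 500 ug/mL in this assay

Of the compounds shown here, three sharing the same core have been tested in this assay. Compound 1 stands at the lowest number of the three and therefore shows the strongest inhibition of growth. Compound 2 lies far higher, well beyond the scatter of the measurement, and compound 3 higher still. Going by the values given here, no pair of these three differs in just one place, so what the two larger compounds show is simply that replacing the open amine of compound 1 by one or two phenylpiperazine groups goes along with much weaker inhibition.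

Compound 4, `Cc1ccc(CNCc2cc(C)n(-c3ccc(Cl)cc3)c2C)cc1`, has not yet been measured. It differs from compound 1 in a single spot: methyl in place of chloro on an aromatic carbon. The group that leaves and the group that enters are each a single heavy atom, neither carries a donor, an acceptor or a charge, and no ring is added or lost. Among the compounds with values here, nothing among the measured compounds probes this exact exchange.

For such a small change the expected step from compound 1 to compound 4 is small, a 2.0-fold higher number from compound 1 to compound 4 (0.30 log units; within the scatter), most likely within the scatter or only slightly upward. Compound 4 is therefore estimated at 0.2 ug/mL, with a plausible range from 0.05 ug/mL to 1 ug/mL.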

Compound 4, concentration for 50% growth inhibition: 0.1 ug/mL
Estimate against measurement, compound 4: 2.0-fold (0.30 log units) above; low and high end bracket the measured number.
By their numbers in this assay, from the lowest: compounds 1 and 4 (each within the scatter of the next); then compound 2; then compound 3.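

Going by these compounds alone, compound 1 and compound 4 are the first pair here that differ in one place only, so this exchange can now be read directly: in this assay, going from 4-chlorobenzyl to 4-methylbenzyl gives no change at the digits printed from compound 1 to compound 4 (within the scatter). At this spot on the ring, this read-out does not tell chloro and methyl apart, and the strong inhibition of growth seen with compound 1 survives the loss of this chlorine as long as methyl takes its place. Nothing available explains why the two groups give the same number.

Going by these compounds, this is a single exchange at a single spot, so it remains open whether the same holds for groups of a different kind there, such as a carboxylic acid, an amine or a longer chain like butyl. The pair also says nothing about the second chlorine or the open amine, since compound 1 and compound 4 share both, and how much each of them contributes to the growth inhibition cannot be judged from these two compounds.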